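The source may report more compounds than this note shows. Statements on the series, on what has been measured and on what is new or still open speak of the compounds shown alone.

In an assay on CHO cells for displacement of a labelled ligand from Alpha-1B adrenergic receptor (Homo sapiens), with a stated time of 30 min (on this read-out higher numbers stand for weaker inhibition and lower numbers for stronger inhibition), compound 1 `COc1cc2nc(N3CCC[C@@H](N)C3)nc(N)c2cc1OC` gives 178 nM, the highest of the two numbers measured. Compound 2 `COc1cc2nc(N3CCC[C@H](N)C3)nc(N)c2cc1OC` gives 55 nM; the step of a 3.2-fold lower number from compound 1 to compound 2 (0.51 log units; beyond the scatter) rests on the fact that compounds 1 and 2 differ only in the configuration as drawn alone. Compound 3 `COc1cc2nc(N3CCC[C@@H](NC(=O)c4ccco4)C3)nc(N)c2cc1OC` carries (furan-2-yl)carbonyl in place of hydrogen on an amine nitrogen. For the measured compounds named here, no measured step alters the atoms in this way; the configurational step from compound 1 to compound 2 is the only comparison at hand, and it gives no direct guide for the added group. The number for compound 3 is therefore expected to lie close to that of compound 1, a 1.8-fold lower number from compound 1 to compound 3 (0.25 log units; within the scatter), with wide uncertainty. The estimate for compound 3 is 100 nM, between 15 nM and 600 nM.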

Compound 3, inhibition constant: 42.7 nM
For compound 3 the middle estimate is 2.3-fold (0.37 log units) above the measured one; measured number inside the range.
By their numbers in this assay, from the lowest: compounds 3 and 2 (each within the scatter of the next); then compound 1.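

Compound 3 shows that the amine nitrogen need not stay free: in this assay, (furan-2-yl)carbonyl in place of hydrogen there brings a 4.2-fold lower number from compound 1 to compound 3 (0.62 log units; beyond the scatter), so inhibition grows stronger with this added group. Nothing in the data at hand explains this gain.

On these data alone, whether the furan ring matters, or the carbonyl alone would do, stays open, and a smaller acetyl group or a phenyl-bearing benzoyl group could separate the two. Also open, as far as these compounds go, is how (furan-2-yl)carbonyl behaves on the amine of compound 2, with its opposite configuration.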